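Bromo Added to the Fluorophenyl Group of Compound 2

The compounds below may be only part of what the source reports. "The series", "measured", "known", "first", "only" and "open" are said of these compounds alone.

Two compounds share one core and differ only in the group on the phenyl ring. Compound 1 `COc1ccc(-c2cc(=O)c3c(O)cc(OCCCCN4CCN(C)CC4)c(OC)c3o2)cc1` carries a methoxy there, and in a functional assay on A549 cells (Homo sapiens) for cytotoxicity, read by MTT assay, with a stated time of 72 h (a lower number here means a stronger inhibitor, a higher number a weaker inhibitor), compound 1 gives 2320 nM. Compound 2 `COc1c(OCCCCN2CCN(C)CC2)cc(O)c2c(=O)cc(-c3ccc(F)cc3)oc12` carries a fluoro instead, and in this assay compound 2 gives 2220 nM. The step of a 1.0-fold lower number from compound 1 to compound 2 (0.02 log units; within the scatter) is within the scatter, so the two numbers cannot be told apart. Compound 3 `COc1c(OCCCCN2CCN(C)CC2)cc(O)c2c(=O)cc(-c3ccc(F)cc3Br)oc12` is the next step: bromo in place of hydrogen on an aromatic carbon. Among the measured compounds shown here, the only measured step swaps one group for another on this ring; no measured step adds a group next to an existing one, so nothing measured bears directly on the change. Without such a guide, the estimated step of a 1.0-fold lower number from compound 2 to compound 3 (0.00 log units; within the scatter) is none beyond the scatter. Compound 3 is therefore expected to give about 2200 nM in this assay, within a range of 900 nM to 5500 nM.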

Compound 3, half-maximal inhibitory concentration: 2980 nM
For compound 3 the middle estimate is 1.4-fold (0.13 log units) below the measured one, and the stated range covers the measured number.
By their numbers in this assay, from the lowest: compounds 2, 1 and 3 (each within the scatter of the next).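

In this assay, a bromo on an aromatic carbon, ortho to a large group and meta to the fluoro group, gives a 1.3-fold higher number from compound 2 to compound 3 (0.13 log units; within the scatter). This is the first step shown that adds a group to this ring instead of swapping one, and the number does not move beyond the usual spread of repeat measurements; the same holds when the whole aryl group is compared, with a 1.3-fold higher number from compound 1 to compound 3 (0.11 log units; within the scatter). No measurement here offers an explanation for this result.

On these data alone, it remains open whether a different group at this same ring position, such as an amine or a carboxylic acid, would shift the number beyond the scatter. As far as these compounds go, it is also open whether a bromo would behave the same way on the 4-methoxyphenyl group of compound 1.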